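A few compounds are considered here, and "the series" means these few. Any claim that something is new, unique, unknown or untested is made for them only; others in the source may bear on it.

Measured so far:
compound 1 `CN1CCc2nc(C#Cc3cccc(Cl)c3)ccc2C1=O` — 250 nM
compound 2 `Cc1cccc(C#Cc2ccc3c(n2)CCN(C2CCCC2)C3=O)c1` — 670 nM
compound 3 `O=C1c2ccc(C#Cc3ccccc3Cl)nc2CCN1C1CCCC1` — > 32000 nM

In an assay on HEK293 cells for displacement of a labelled ligand from metabotropic glutamate receptor 5 (Homo sapiens), with a stated time of 2 h (a lower number here means a stronger inhibitor, a higher number a weaker inhibitor), compound 1 gives 250 nM and compound 2 gives 670 nM. For compound 3 this assay reports only a limit, > 32000 nM. That limit is the limit of > 32000 nM in this assay, at which 1 of the 3 values shown sits, so compound 3 stands outside the measurable range and has no number of its own. Among the measured compounds shown here, the one measured step that bears on the present question is an at least 47-fold higher number from compound 2 to compound 3 (1.67 log units; beyond the scatter): 2-chlorophenyl on the triple-bonded carbon is at the limit where 3-methylphenyl gives a measurable value.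

Compound 4 `O=C1c2ccc(C#Cc3cccc(Cl)c3)nc2CCN1C1CCCC1` has not yet been measured. It differs from compound 3 by 3-chlorophenyl in place of 2-chlorophenyl on a triple-bonded carbon. Compound 1 also carries 3-chlorophenyl on the triple-bonded carbon, with a different group on the amide nitrogen of the shared core, and gives 250 nM. Compound 2 carries 3-methylphenyl with the same cyclopentyl as compound 4, and in this assay compound 2 gives 670 nM. Both point to a measurable number for compound 4. The step is therefore expected to be large, towards a lower number, an at least 64-fold lower number from compound 3 to compound 4 (1.80 log units; beyond the scatter). The estimate for compound 4 in this assay is 500 nM, with a range of 150 nM to 2000 nM.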

Compound 4, inhibition constant: 5230 nM
Estimate against measurement, compound 4: 10-fold (1.02 log units) below, and the stated range ends below it.
By their numbers in this assay, from the lowest: compound 1; then compound 2; then compound 4. At a limit, above all of these: compound 3.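

In this assay, 3-chlorophenyl in place of 2-chlorophenyl on the triple-bonded carbon brings the cyclopentyl series back to a measurable value (an at least 6.1-fold lower number from compound 3 to compound 4 (0.78 log units; beyond the scatter)), and this step is only a bound, as the value for compound 3 is a limit: the limit of > 32000 nM in this assay, at which 1 of the 4 values shown sits.
Among the measurable compounds that carry cyclopentyl, the group on the triple-bonded carbon still matters: chloro in place of methyl on an aromatic carbon gives a 7.8-fold higher number from compound 2 to compound 4 (0.89 log units; beyond the scatter) and so separates 3-chlorophenyl from 3-methylphenyl beyond the scatter. 3-Chlorophenyl does not set the number by itself either, since cyclopentyl in place of methyl on the amide-type nitrogen in a ring gives a 21-fold higher number from compound 1 to compound 4 (1.32 log units; beyond the scatter) with that group unchanged.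

The compounds shown leave open whether 2-chlorophenyl also ends at a limit with methyl on the amide-type nitrogen, and whether 3-methylphenyl with methyl there would outdo 3-chlorophenyl. They also say nothing about ethyl or cyclopropyl on that nitrogen, or about a fluorophenyl or pyridine ring on the triple-bonded carbon.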